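This account rests on a few compounds, and the source may have more. Where it says the series, first, only, none or still open, it means among the compounds named here.

Compound 1 `Clc1ccccc1CSc1nnc(-c2cnccn2)o1` and compound 2 `Brc1ccccc1CSc1nnc(-c2cnccn2)o1` share one core, while compound 3 `Clc1ccc(CSc2nnc(-c3cnccn3)s2)cc1` is built on a second core, which compound 4 `Brc1ccc(CSc2nnc(-c3cnccn3)s2)cc1` also carries. In a functional assay on BGC-823 cells (Homo sapiens) for antiproliferative activity, read by MTT assay, with a stated time of 48 h (on this read-out lower numbers stand for stronger inhibition and higher numbers for weaker inhibition), compound 1 gives 27700 nM, and compound 2 gives 17600 nM. The step between them, a 1.6-fold lower number from compound 1 to compound 2 (0.20 log units; within the scatter), comes from a single change in the structure, (bromo in place of chloro on an aromatic carbon). Compound 3 gives 13400 nM in this assay; set against compound 1 this difference lies beyond the scatter, set against compound 2 it lies within it. How the core of compound 3 differs from the core of compound 1 is not broken down here. Compound 4 differs from compound 3 in one place, (bromo in place of chloro on an aromatic carbon). Going by the values given here, this is the same kind of change as the one between compound 1 and compound 2, yet not the same change: in compound 1 the place is ortho to a large group, whereas in compound 3 it is para to a large group. Since the earlier change gave a 1.6-fold lower number from compound 1 to compound 2 (0.20 log units; within the scatter), a step of similar size is expected in this assay, namely a 1.6-fold lower number from compound 3 to compound 4 (0.20 log units; within the scatter). Among the compounds with values here, the single earlier example is a thin basis, so the expected range is kept wide. On that basis compound 4 is estimated to give 8500 nM in this assay, most likely falling between 4500 nM and 18000 nM.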

Compound 4, half-maximal inhibitory concentration: 25200 nM
Compound 4: middle estimate off by 3.0-fold (0.47 log units), on the low side; the measured number lies above the stated range.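

In this assay, putting bromo in place of chloro on the core of compound 3 gives a 1.9-fold higher number from compound 3 to compound 4 (0.27 log units; within the scatter), so this step taken alone is no real difference. Set beside the earlier step, the two point in opposite directions, which shows that in this series the effect of this swap cannot simply be carried over as a fixed amount from one core to the other: the same change on two cores in this assay, a 1.6-fold lower number (0.20 log units; within the scatter) from compound 1 to compound 2 and a 1.9-fold higher number (0.27 log units; within the scatter) from compound 3 to compound 4, 3.0-fold (0.47 log units) apart, beyond the scatter of two such steps. Going by these compounds alone, this does not show why the two steps disagree, since the two pairs differ both in their core and in where the swap sits on the aromatic ring, and with only one step on each core, neither cause can be separated from the other or from chance in the individual readings.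

The compounds shown leave open whether the core or the place on the ring decides the outcome, a question that the same swap at the same place on both cores could answer. They also leave open how other groups at that place on the six-membered ring, such as a methoxy group, an amine or a carboxylic acid, would compare with the two halogens.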